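A few compounds are considered here, and "the series" means these few. Any claim that something is new, unique, unknown or untested is made for them only; others in the source may bear on it.

The series shares one core, shown for compound 1 as `COC(OC)C1=C(C(=O)OC/C=C/c2ccccc2Cl)C(c2cccc(Cl)c2)C(C(=O)O)=C(C)N1`. In an assay on thoracic aorta for inhibition of Voltage-gated L-type calcium channel (Rattus norvegicus) (on this read-out higher numbers stand for weaker inhibition and lower numbers for stronger inhibition), compound 1 gives 700 nM. Compound 2, `COC(OC)C1=C(C(=O)OC/C=C/c2ccc(Cl)cc2)C(c2cccc(Cl)c2)C(C(=O)O)=C(C)N1`, differs from it only in the aryl at the end of the ester chain; in this assay compound 2 gives 1400 nM. Among the compounds with values here, the single measured step is a 2.0-fold higher number from compound 1 to compound 2 (0.30 log units; within the scatter). Compound 2 thus holds the higher of the two numbers, but its gap to compound 1 is within the scatter, so the two read as equivalent in this assay.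

Compound 3, `COC(OC)C1=C(C(=O)OC/C=C/c2ccc(F)cc2)C(c2cccc(Cl)c2)C(C(=O)O)=C(C)N1`, is not yet measured. Against compound 2 the change is fluoro in place of chloro on an aromatic carbon, para to a large group on the six-membered aromatic ring of carbon only. Within the data shown here, no measured pair exchanges one halogen for another on this ring; the only step at hand, a 2.0-fold higher number from compound 1 to compound 2 (0.30 log units; within the scatter), concerns the chloro alone and stays within the scatter. Nothing here points to a shift beyond the scatter in this assay in either direction. The estimate for compound 3 is therefore 1500 nM, with a range of 600 nM to 4000 nM. This amounts to an expected step of a 1.1-fold higher number from compound 2 to compound 3 (0.03 log units; within the scatter), judged to lie within the scatter.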

Compound 3, half-maximal inhibitory concentration: 2000 nM
Beside the measured number, compound 3's estimate is 1.3-fold (0.12 log units) below it; low and high end bracket the measured number.
By their numbers in this assay, from the lowest: compounds 1, 2 and 3 (each within the scatter of the next, the first and the last beyond it).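

Within the data shown here, on the ring at the end of the ester chain, fluoro in place of chloro, para to a large group, gives a 1.4-fold higher number from compound 2 to compound 3 (0.15 log units; within the scatter) and so leaves compound 2 and compound 3 equivalent in this assay; this is the first halogen exchange on this ring, and it does not separate the pair. The comparison with the 2-chlorophenyl compound gives a 2.9-fold higher number from compound 1 to compound 3 (0.46 log units; beyond the scatter) as a modest step and the first in the series to lie beyond the scatter, whereas 4-chlorophenyl in place of 2-chlorophenyl gave a 2.0-fold higher number from compound 1 to compound 2 (0.30 log units; within the scatter) and stayed within it. No measurement at hand offers an explanation for these numbers.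

The compounds shown leave open whether the separation between compound 1 and compound 3 comes from the halogen or from its place on the ring, a question that a 2-fluorophenyl analogue would address. They also leave open how this ring responds to groups other than halogens, such as a methoxy group, an amine or a carboxylic acid, or to an unsubstituted phenyl.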